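Aryl hydrazone series: pyridin-4-yl replacing bromofluorophenyl

The compounds below may be only part of what the source reports. "The series", "measured", "known", "first", "only" and "open" are said of these compounds alone.

Among the measured compounds shown here, compound 3 `O=C(N/N=C/c1ccc(F)c(Br)c1)c1ccc(-c2nc3ccccc3s2)cc1` gives 28000 nM in an assay on isolated protein for inhibition of Maltase-glucoamylase (Homo sapiens), with a stated time of 15 min (a higher number here means a weaker inhibitor, a lower number a stronger inhibitor), the highest number of the three measured members. Compound 1 `O=C(N/N=C/c1ccc(O)cc1)c1ccc(-c2nc3ccccc3s2)cc1` gives 11300 nM in this assay, and compound 2 `COc1ccc(/C=N/NC(=O)c2ccc(-c3nc4ccccc4s3)cc2)c(O)c1` gives 6970 nM. The steps onto compound 3 are a 2.5-fold higher number from compound 1 to compound 3 (0.39 log units; beyond the scatter) and a 4.0-fold higher number from compound 2 to compound 3 (0.60 log units; beyond the scatter), both modest and both pointing to the 3-bromo-4-fluorophenyl group as the weakest option so far.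

Compound 4 `O=C(N/N=C/c1ccncc1)c1ccc(-c2nc3ccccc3s2)cc1` carries the change (pyridin-4-yl in place of 3-bromo-4-fluorophenyl on a carbon with a double bond to nitrogen). For the measured compounds named here, no measured step involves a nitrogen-containing aromatic ring at this position, so the two steps onto compound 3 only suggest that leaving the 3-bromo-4-fluorophenyl group should recover some potency. Compound 4 is therefore expected to show a 2.0-fold lower number from compound 3 to compound 4 (0.30 log units; within the scatter), moving back into the region of the hydroxyphenyl members. Compound 4 is estimated at 14000 nM, within a range from 6000 nM to 35000 nM.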

Compound 4, half-maximal inhibitory concentration: "not active" (no number reported)
For compound 4 the study gives words and no number, and the estimate cannot be compared.
By their numbers in this assay, from the lowest: compounds 2 and 1 (each within the scatter of the next); then compound 3.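

Among the compounds shown here, compound 4 is reported in this assay only in words, so no step linking it to compound 3 or any other compound can be read. Nothing shown bears on this result. From the compounds shown here alone, how pyridin-4-yl compares numerically with the other groups at this place stays open.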